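The compounds below may be only part of what the source reports. "The series", "measured", "known", "first", "only" and "open" are said of these compounds alone.

Of the compounds shown here, three carrying the shared core have been measured in a functional assay on CHO cells for antagonist activity at corticotropin-releasing factor receptor 1 (Homo sapiens), read by cAMP accumulation; on this read-out higher numbers stand for weaker inhibition and lower numbers for stronger inhibition. Compound 1 `COc1ccc(-n2ncc3c(NC(C4CC4)C4CC4)nc(C)nc32)c(C)c1` gives 32 nM, compound 2 `COc1ccc(-n2c(CC3CC3)nc3c(NC(C4CC4)C4CC4)nc(C)nc32)cc1` gives 308 nM, and compound 3 `Cc1nc(NC(C2CC2)C2CC2)c2nc(C)n(-c3ccc(C#N)cc3)c2n1` gives 62 nM. Compound 3 thus stands second highest of the three numbers: its nearest neighbour is compound 1, whose number is lower but within the scatter, while compound 2 sits furthest away with a number beyond the scatter. Compound 4 `CCOc1ccc(-n2c(C)nc3c(NC(C4CC4)C4CC4)nc(C)nc32)cc1` has not yet been measured. It differs from compound 3 in one place: ethoxy in place of cyano on an aromatic carbon. Going by the values given here, with no measured pair showing this change on its own, no step beyond the scatter is expected, so that the move from compound 3 to compound 4 is estimated as a 1.2-fold higher number from compound 3 to compound 4 (0.08 log units; within the scatter). In this assay compound 4 is expected to give 75 nM, most likely between 20 nM and 250 nM.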

Compound 4, inhibition constant: 20 nM
Compound 4: middle estimate off by 3.8-fold (0.57 log units), on the high side, within the range that was stated.
By their numbers in this assay, from the lowest: compounds 4, 1 and 3 (each within the scatter of the next, the first and the last beyond it); then compound 2.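

In this assay, going by these compounds alone, replacing 4-cyanophenyl with 4-ethoxyphenyl gives a 3.1-fold lower number from compound 3 to compound 4 (0.49 log units; beyond the scatter) and this is the first measured change on this aromatic carbon, para to a large group. It shows that the group held here can move the number beyond the scatter, with ethoxy giving the lower number of the pair. The data offer no measured explanation for this step. From the compounds shown here alone, whether a longer propoxy chain, an amine or a carboxylic acid at this place would go with a lower or a higher number stays open. So does whether the same change would give a similar step on another core.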